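Chloro Added Beside the Anilino Ester of Compound 3

The source may hold more compounds than are shown below. What is called first, only, known or untested is meant among the compounds shown, and "the series" means these compounds.

Compound 1 `CCS(=O)(=O)Nc1cc(-c2ccc3ncnc(Nc4ccc(F)cc4F)c3c2)cnc1OC`: 4710 nM
Compound 2 `CCS(=O)(=O)Nc1cc(-c2ccc3ncnc(Nc4ccc(OC)c(OC)c4)c3c2)cnc1OC`: 5820 nM
Compound 3 `CCS(=O)(=O)Nc1cc(-c2ccc3ncnc(Nc4cccc(C(=O)OC)c4)c3c2)cnc1OC`: 1100 nM

Of the compounds shown here, three sharing one core have been measured in a functional assay on A549 cells (Homo sapiens) for cytotoxicity, read by sulforhodamine B assay, with a stated time of 72 h (a higher number here means a weaker inhibitor, a lower number a stronger inhibitor), and differ only in the aryl group carried on the anilino nitrogen. Compound 3 stands lowest of the three: the step of a 4.3-fold lower number from compound 1 to compound 3 (0.63 log units; beyond the scatter) and the step of a 5.3-fold lower number from compound 2 to compound 3 (0.72 log units; beyond the scatter) both lie beyond the scatter, whereas the step of a 1.2-fold higher number from compound 1 to compound 2 (0.09 log units; within the scatter) does not. Compound 4 `CCS(=O)(=O)Nc1cc(-c2ccc3ncnc(Nc4ccc(Cl)c(C(=O)OC)c4)c3c2)cnc1OC` is the next member, and it differs from compound 3 by chloro in place of hydrogen on an aromatic carbon. Among the compounds with values here, no measured pair reproduces this change; the only steps that bear on it are the two just named, which show that replacing the whole aryl group on that nitrogen moves the number modestly, while a single small substituent added to the same ring has not yet been tested. Given that, the step of a 1.1-fold lower number from compound 3 to compound 4 (0.04 log units; within the scatter) is expected to stay within the scatter. Compound 4 is therefore estimated at 1000 nM, with a range from 400 nM to 3000 nM.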

Compound 4, half-maximal inhibitory concentration: 2130 nM
Compound 4: the middle estimate sits 2.1-fold (0.33 log units) below what was measured, within the range that was stated.
By their numbers in this assay, from the lowest: compounds 3 and 4 (each within the scatter of the next); then compounds 1 and 2 (each within the scatter of the next).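

In this assay, within the data shown here, chloro in place of hydrogen, ortho to a methoxycarbonyl group and para to a large group, is the first single small substituent tried on this ring, and it gives a 1.9-fold higher number from compound 3 to compound 4 (0.29 log units; within the scatter) so this carbon tolerates chloro without a change beyond the scatter. The chloro compound also keeps the separation from the two aryl groups lacking the ester, with a 2.7-fold lower number from compound 2 to compound 4 (0.44 log units; beyond the scatter) and a 2.2-fold lower number from compound 1 to compound 4 (0.34 log units; beyond the scatter) both printed as beyond the scatter, as was true of compound 3. Nothing measured here explains these numbers.

The compounds shown leave open whether fluoro, methyl or an amine on the same carbon would read as chloro does. They also do not tell how a carboxylic acid or an amide would stand in place of the methoxycarbonyl group.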